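The source may report more compounds than this note shows. Statements on the series, on what has been measured and on what is new or still open speak of the compounds shown alone.

In a functional assay on Jurkat cells (Homo sapiens) (on this read-out higher numbers stand for weaker inhibition and lower numbers for stronger inhibition), compound 1 `C[C@H](NC(=O)C(=O)NCCC1CCCC1)C(=O)N[C@@H](CC(=O)O)C(=O)COc1c(F)c(F)cc(F)c1F` gives 11 nM and compound 2 `C[C@H](NC(=O)C(=O)Nc1cccnc1N(C)C)C(=O)N[C@@H](CC(=O)O)C(=O)COc1c(F)c(F)cc(F)c1F` gives 27 nM on the shared core. Compound 3 `C[C@H](NC(=O)C(=O)NCc1ccccc1F)C(=O)N[C@@H](CC(=O)O)C(=O)COc1c(F)c(F)cc(F)c1F` gives 207 nM as the highest number of the three and is the weakest inhibitor so far. The measured gaps to it are a 7.7-fold higher number from compound 2 to compound 3 (0.88 log units; beyond the scatter) and a 19-fold higher number from compound 1 to compound 3 (1.27 log units; beyond the scatter) and both lie beyond the scatter.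

Compound 4 `C[C@H](NC(=O)C(=O)NCc1cccc(F)c1)C(=O)N[C@@H](CC(=O)O)C(=O)COc1c(F)c(F)cc(F)c1F` carries 3-fluorophenyl in place of 2-fluorophenyl on a saturated chain carbon bound to an amide-type nitrogen. Among the measured compounds shown here, no measured step covers a change of this kind. The step of a 2.5-fold higher number from compound 1 to compound 2 (0.39 log units; beyond the scatter) and the two steps into compound 3 each replace the whole group on the amide-type nitrogen, and none keeps the same atoms while joining them differently. Those steps therefore set no size or direction for this change, and compound 3 at 207 nM remains the only usable anchor.

The estimated change is a 1.2-fold lower number from compound 3 to compound 4 (0.09 log units; within the scatter) in this assay and no step beyond the scatter is expected, with neither direction favoured. For compound 4 the expected value is 170 nM with an estimated range from 60 nM to 500 nM in this assay as the working figure.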

Compound 4, half-maximal inhibitory concentration: 106 nM
Beside the measured number, compound 4's estimate is 1.6-fold (0.21 log units) above it; the range from low to high includes it.
By their numbers in this assay, from the lowest: compound 1; then compound 2; then compounds 4 and 3 (each within the scatter of the next).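

In this assay, among the compounds shown here, 3-fluorobenzyl in place of 2-fluorobenzyl on the amide-type nitrogen gives a 2.0-fold lower number from compound 3 to compound 4 (0.29 log units; within the scatter) and is the first change here that keeps the same atoms and joins them differently. In this pair, the fluorine placement on the benzyl group therefore gives no step beyond the scatter. The other two new steps are a 3.9-fold higher number from compound 2 to compound 4 (0.59 log units; beyond the scatter) and a 9.6-fold higher number from compound 1 to compound 4 (0.98 log units; beyond the scatter), so the higher numbers relative to the 2-(dimethylamino)pyridin-3-yl and 2-cyclopentylethyl compounds now hold for both fluorobenzyl compounds rather than resting on 2-fluorobenzyl alone. No accompanying measurement bears on these results, and the numbers alone offer no explanation for the steps.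

The compounds shown leave open how unsubstituted benzyl, or chlorine in place of the fluorine, would read on this nitrogen. They also leave open whether a longer chain such as 2-phenylethyl would come closer to compound 1, and thus whether the chain or the ring type carries the gap between compound 1 and the fluorobenzyl compounds.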